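A few compounds are considered here, and "the series" means these few. Any claim that something is new, unique, unknown or untested is made for them only; others in the source may bear on it.

Three compounds on the shared core have entries so far in a functional assay on A549 cells (Homo sapiens) for inhibition, read by sulforhodamine B assay, with a stated time of 48 h; on this read-out lower numbers stand for stronger inhibition of growth and higher numbers for weaker inhibition of growth. Within the data shown here, compound 3 `CCCCNC(=[Se])Nc1ccc2c(C)cc(=O)oc2c1` gives 3000 nM, the only actual number in the set. Compound 1 `COC(=[Se])Nc1ccc2c(C)cc(=O)oc2c1` stands at > 100000 nM, which is a limit of the assay and not a number. Compound 2 `CCCCOC(=[Se])Nc1ccc2c(C)cc(=O)oc2c1` has no result, and its entry reads "nd(insoluble)" (no result reported).

The next change leads to compound 4 `Cc1cc(=O)oc2cc(NC(=[Se])Nc3ccccc3)ccc12`: phenyl in place of butyl on an amine nitrogen. In short, butylamino becomes anilino. Among the measured compounds shown here, the one measured step that bears on this is an at least 33-fold lower number from compound 1 to compound 3 (1.52 log units; beyond the scatter), a large change with butylamino in place of methoxy. It shows that this assay can respond strongly to a change at this part of the structure, but it replaces the group as a whole and not the butyl alone. For the measured compounds named here, no measured pair compares a chain with a ring on the amine nitrogen, so neither the size nor the direction of the new step can be read directly from the data.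

The working expectation therefore stays anchored on compound 3 at 3000 nM, with a wide margin on both sides. The expected change is a 1.2-fold lower number from compound 3 to compound 4 (0.08 log units; within the scatter), which would lie within the scatter. Compound 4 is estimated at 2500 nM, with an expected range of 500 nM to 12000 nM.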

Compound 4, concentration for 50% growth inhibition: 28000 nM
The estimate for compound 4 lay 11-fold (1.05 log units) below the measured number; measured number outside the range, above it.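

Setting butyl against phenyl on the same amine nitrogen isolates what the step from the methoxy compound could not: in this assay, the change gives a 9.3-fold higher number from compound 3 to compound 4 (0.97 log units; beyond the scatter), so the group carried by this nitrogen matters in its own right, and here the chain gives the lower number. The anilino group still gives an at least 3.5-fold lower number from compound 1 to compound 4 (0.55 log units; beyond the scatter), so compound 3 and compound 4, the two compounds with a substituted amine nitrogen at this place, both lie on the lower side of the methoxy compound, although they differ clearly from each other. The entry for compound 1 is a limit of the assay and not a number, so this second step is a bound only: the limit of > 100000 nM in this assay, at which 1 of the 4 values shown sits.

Going by these compounds, with only butyl and phenyl on the amine nitrogen, it remains open whether the higher number follows the aromatic ring itself or the shape of the group, a question that cyclohexyl or benzyl on this nitrogen would address, while methyl or a longer chain such as hexyl would show how far chain length counts. Compound 2 has no number, so the butyl chain on oxygen cannot be set against butylamino in compound 3.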